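A few compounds are considered here, and "the series" means these few. Any claim that something is new, unique, unknown or untested is made for them only; others in the source may bear on it.

Working notes on the series.

The series shares a core carrying a thiocarbonyl; the groups attached to that carbon vary. Compound 1 `Nc1ccccc1NC(=O)c1ccc(CSC(=S)N2CCN(c3ccccc3)CC2)cc1` is measured in a functional assay on HeLa cells (Homo sapiens) for antiproliferative activity, read by CCK-8 assay, with a stated time of 72 h, tested at 2 uM (a higher number here means a stronger effect of the compound at the concentration tested, a lower number a weaker effect), and gives 62.2%. Within the data shown here, compound 3 `N#Cc1ccc(N2CCN(C(=S)SCc3ccc(C(=O)Nc4ccccc4N)cc3)CC2)cc1` gives 71.6% in this assay; the step of a number 9.4 percentage points higher from compound 1 to compound 3 (within the scatter) is the only single-point change measured so far. Compound 2 `Nc1ccccc1NC(=O)c1ccc(CSC(=S)N2CCc3cc(Cl)ccc32)cc1` gives 40.1% in this assay, the lowest of the three numbers, with compound 1 nearest and compound 3 furthest, both beyond the scatter.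

Compound 4 `CN(Cc1ccncc1)C(=S)SCc1ccc(C(=O)Nc2ccccc2N)cc1` is not yet measured. Its change from compound 2 is methyl((pyridin-4-yl)methyl)amino in place of 5-chloro-2,3-dihydro-1H-indol-1-yl on a thiocarbonyl carbon. Among the measured compounds shown here, no measured step concerns this place on the thiocarbonyl carbon; the step from compound 1 to compound 3 sits on an aromatic carbon and is within the scatter, so it gives little guidance. Compounds 1 and 2 carry different groups on that carbon and their values differ beyond the scatter, so a change here may move the number. In this assay compound 4 is expected to give 50%, between 30% and 72%, a step of a number 9.9 percentage points higher from compound 2 to compound 4 (within the scatter), estimated with low confidence.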

Compound 4, a percentage reported as inhibition, at one concentration (the size of the read-out at that concentration, not a potency): 29.5%
For compound 4 the middle estimate is 20.5 percentage points above the measured one; measured number outside the range, below it.
By their numbers in this assay, from the lowest: compound 4; then compound 2; then compounds 1 and 3 (each within the scatter of the next).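

Among these compounds, on the thiocarbonyl carbon, in this assay the exchange of 5-chloro-2,3-dihydro-1H-indol-1-yl for methyl((pyridin-4-yl)methyl)amino gives a number 10.6 percentage points lower from compound 2 to compound 4 (beyond the scatter) and is the first single-place change at this carbon with a reading of its own. Until now, this position had been compared only through compounds 1 and 2, whereas this step shows directly that a change on this carbon alone can move the number beyond the scatter, though only modestly. Nothing available explains the step.

The change swaps the whole group at once, so the pyridine nitrogen, the methyl on the amine nitrogen and the loss of the chlorine cannot be told apart. A benzyl(methyl)amino group, with a plain phenyl ring in place of the pyridine, or a morpholine on the same carbon would be needed to separate these parts.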